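From Compound 1 to Compound 3: an Untested Ring Exchange

This account rests on a few compounds, and the source may have more. Where it says the series, first, only, none or still open, it means among the compounds named here.

Compound 1 `OC(c1ccc(Cl)cc1)(c1cccnc1)c1ccccc1Cl` is one of two compounds tested in an ADME assay on L6 cells (Rattus norvegicus) for cytotoxicity, read by resazurin assay, with a stated time of 72 h (a higher number here means a weaker inhibitor, a lower number a stronger inhibitor), in which compound 1 gives 61300 nM. Its nearest neighbour is compound 2 `Clc1ccc(C(c2cccnc2)c2ccccc2Cl)cc1`, which gives 62300 nM in this assay; the step of a 1.0-fold higher number from compound 1 to compound 2 (0.01 log units; within the scatter) leaves the two on the same footing. Compound 3 `OC(c1ccc(Cl)cc1)(c1cccnc1)c1nccs1` differs from compound 1 elsewhere: 1,3-thiazol-2-yl in place of 2-chlorophenyl on a saturated chain carbon bound to two aromatic carbons and an oxygen on a saturated carbon. Among the measured compounds shown here, the single measured step concerns hydrogen in place of hydroxy and bears not at all on 1,3-thiazol-2-yl replacing 2-chlorophenyl, so no step beyond the scatter is expected, giving a 1.0-fold lower number from compound 1 to compound 3 (0.01 log units; within the scatter). Compound 3 is therefore estimated at 60000 nM, within 20000 nM to 180000 nM, in this assay.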

Compound 3, half-maximal inhibitory concentration: > 100000 nM
Compound 3 was reported as a limit (the forecaster's own chance of this, stated with the estimate: 25%); middle value at least 1.6-fold (0.22 log units) away from the limit.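

In this assay, 1,3-thiazol-2-yl in place of 2-chlorophenyl on a saturated chain carbon bound to two aromatic carbons and an oxygen on a saturated carbon gives an at least 1.6-fold higher number from compound 1 to compound 3 (0.21 log units; that floor lies within the scatter). Among the compounds shown here, this is the first reading at this position, and the exchange gives no lower number, though the floor of the step does not separate the two compounds. For compound 3 the reading is a limit, not a number: the limit of > 100000 nM in this assay, at which 1 of the 3 values shown sits.

From the compounds shown here alone, how far compound 3 truly lies from compound 1 remains open. So does whether an amine or a carboxylic acid in this place would bring the number lower.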